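The source may report more compounds than this note shows. Statements on the series, on what has been measured and on what is new or still open speak of the compounds shown alone.

In a functional assay on the whole organism with Rattus norvegicus as the target (on this read-out lower numbers stand for an effect already at smaller amounts and higher numbers for an effect only at larger amounts of compound), compound 1 `COC(=O)Cn1c(=N)sc2cc(OC(F)(F)F)ccc21` reports only a limit, > 10 mg/kg. Compound 2 `C[S+]([O-])Cn1c(=N)sc2cc(OC(F)(F)F)ccc21` gives 2.3 mg/kg, and compound 3 `CSCCCn1c(=N)sc2cc(OC(F)(F)F)ccc21` gives 4.2 mg/kg. Compound 3 therefore stands level with compound 2, a 1.8-fold higher number from compound 2 to compound 3 (0.26 log units; within the scatter). Compound 4 `CNCCn1c(=N)sc2cc(OC(F)(F)F)ccc21` carries methylamino in place of (methylsulfanyl)methyl, on a saturated chain carbon, two bonds along the chain from an aromatic nitrogen (methylamino in place of (methylsulfanyl)methyl on a saturated chain carbon, two bonds along the chain from an aromatic nitrogen). The relevant steps all change this chain: an at least 4.3-fold lower number from compound 1 to compound 2 (0.63 log units; beyond the scatter), and an at least 2.3-fold lower number from compound 1 to compound 3 (0.37 log units; beyond the scatter). Among the measured compounds shown here, no measured step tests a chain with methylamino. With the step between compound 2 and compound 3 inside the scatter, the expected change is a 1.1-fold higher number from compound 3 to compound 4 (0.03 log units; within the scatter), which is no step beyond the scatter. The estimate for compound 4 is 4.5 mg/kg, with an expected range of 1.5 mg/kg to 13 mg/kg.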

Compound 4, dose for half-maximal effect: > 10 mg/kg
Compound 4 was reported as a limit (the forecaster's own chance of this, stated with the estimate: 20%); at least 2.2-fold (0.34 log units) between middle value and limit.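

In this assay, the chain does not accept every group at this place: an at least 2.3-fold higher number from compound 3 to compound 4 (0.37 log units; beyond the scatter), and an at least 4.3-fold higher number from compound 2 to compound 4 (0.63 log units; beyond the scatter). The sulfur-bearing chains of compound 2 and compound 3 lie within the scatter of each other, so methylamino in place of (methylsulfanyl)methyl is the first change shown to separate two chains that both give a readable comparison. The pair of compound 1 and compound 4 cannot be read, because both values are limits: the limit of > 10 mg/kg in this assay, at which 2 of the 4 values shown sit.

Open, from the compounds shown here alone, is whether the loss follows the nitrogen itself or the chain length. A longer chain ending in methylamino, or a dimethylamino or hydroxyl group at this place, would separate the two.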